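Trimming the Alkyl Chain: From Compound 2 to Compound 3

The source may hold more compounds than are shown below. What is called first, only, known or untested is meant among the compounds shown, and "the series" means these compounds.

Of the compounds shown here, two have so far been measured in a functional assay on the whole organism with Rattus norvegicus as the target, in the glucose tolerance test; on this read-out higher numbers stand for an effect only at larger amounts of compound and lower numbers for an effect already at smaller amounts. Compound 1 `CCCCCCC1(C(=O)OC)CO1` gives 10 mg/kg in this assay. Compound 2 `CCCCCCCCCCCCCCC1(C(=O)OC)CO1` gives 4 mg/kg, the lowest of the two numbers, and its gap to compound 1 lies beyond the usual scatter of repeated measurements. Compound 3 `CCCCCCCCCCCCC1(C(=O)OC)CO1` has not yet been measured. It differs from compound 2 in one place: hydrogen in place of ethyl on a saturated chain carbon, ten or more bonds along the chain from a saturated ring carbon. Going by the values given here, no pair of measured compounds differing in only one place is available, so any expectation must rest on the two numbers alone. Because compound 2 gives 4 mg/kg and compound 1 gives 10 mg/kg, a shift toward somewhat higher doses is expected for compound 3, most likely within the scatter. Compound 3 is therefore estimated at 5 mg/kg, within a range from 2.5 mg/kg to 10 mg/kg. The expected step is a 1.3-fold higher number from compound 2 to compound 3 (0.10 log units; within the scatter).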

Compound 3, minimum effective dose: 5 mg/kg
Compound 3: middle estimate and measured number agree at the digits printed; the measured number falls inside the stated range.
By their numbers in this assay, from the lowest: compounds 2, 3 and 1 (each within the scatter of the next, the first and the last beyond it).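

In this assay, hydrogen in place of ethyl on a saturated chain carbon, ten or more bonds along the chain from a saturated ring carbon, gives a 1.3-fold higher number from compound 2 to compound 3 (0.10 log units; within the scatter), so this shortening does not separate the two compounds on this read-out. The other step, hexyl in place of hydrogen on a saturated chain carbon, six bonds along the chain from a saturated ring carbon, gives a 2.0-fold lower number from compound 1 to compound 3 (0.30 log units; within the scatter), so these two compounds cannot be told apart either, and each single change shown here stays inside the usual spread of repeat measurements. Nothing available explains these numbers.

Still open, from the compounds shown here alone, is how a longer chain than that of compound 2 would read in this assay. Also open, going by these compounds, is what a carboxylic acid or an amine on the shared core would do to the minimum effective dose.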